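Triazolyl sulfonamides: aryl swap at the ring nitrogen

The source may hold more compounds than are shown below. What is called first, only, known or untested is meant among the compounds shown, and "the series" means these compounds.

Measured so far:
compound 1 `O=c1[nH]cc(S(=O)(=O)Nc2ccccc2-c2cn(-c3cccc(Cl)c3)nn2)c(=O)[nH]1` — 2270 nM
compound 2 `O=c1[nH]cc(S(=O)(=O)Nc2cccc(-c3cn(-c4ccccc4F)nn3)c2)c(=O)[nH]1` — 16000 nM

In a functional assay on SGC-7901 cells (Homo sapiens) for antiproliferative activity, read by MTT assay, with a stated time of 24 h (on this read-out higher numbers stand for weaker inhibition and lower numbers for stronger inhibition), compound 2 gives 16000 nM, the highest of the two numbers recorded and beyond the scatter from its nearest neighbour. Compound 1 gives 2270 nM, a clearly lower number; the two compounds differ in more than one place, so nothing about a single change is read from that gap. Compound 3 `O=c1[nH]cc(S(=O)(=O)Nc2cccc(-c3cn(-c4ccc(Cl)cc4)nn3)c2)c(=O)[nH]1` is not yet measured. It differs from compound 2 in one place: 4-chlorophenyl in place of 2-fluorophenyl on an aromatic nitrogen. For the measured compounds named here, no pair of measured compounds differs only at this aromatic nitrogen, so the size of the step is not set by the data. A step toward a lower number is expected, of a size near the edge of the scatter rather than clearly beyond it. For compound 3 the estimate is 8000 nM, within a range from 2000 nM to 32000 nM. The expected step is a 2.0-fold lower number from compound 2 to compound 3 (0.30 log units; within the scatter).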

Compound 3, half-maximal inhibitory concentration: 2160 nM
Beside the measured number, compound 3's estimate is 3.7-fold (0.57 log units) above it; the range from low to high includes it.
By their numbers in this assay, from the lowest: compounds 3 and 1 (each within the scatter of the next); then compound 2.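

In this assay, for the compounds shown here, there is a 7.4-fold lower number from compound 2 to compound 3 (0.87 log units; beyond the scatter) with 4-chlorophenyl in place of 2-fluorophenyl on an aromatic nitrogen, the first single change that can be read. The aryl group at this position therefore matters to the read-out, even though both groups have the same heavy-atom count, one six-membered aromatic ring of carbon only, and no hydrogen-bond donors or acceptors. Nothing at hand accounts for the step.

The swap changes both the halogen and where it sits on the phenyl ring, and the compounds shown do not separate these two changes. As far as these compounds go, how an unsubstituted phenyl, a benzyl group, or a phenyl ring carrying an amine or a carboxylic acid would read at this nitrogen remains open.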